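This account rests on a few compounds, and the source may have more. Where it says the series, first, only, none or still open, it means among the compounds named here.

Compound 1 `COc1ccc(-c2[nH]c3ccccc3c2/C=C(\C#N)S(=O)(=O)c2ccccc2)cc1` holds the lowest number of the three measured compounds in a functional assay on MT4 cells (Homo sapiens) for antiproliferative activity, read by MTT assay, with a stated time of 96 h; on this read-out higher numbers stand for an effect only at larger amounts of compound and lower numbers for an effect already at smaller amounts: in this assay compound 1 gives 200 nM. Compound 2 `COc1ccc2[nH]c(-c3ccccc3)c(C=C(C#N)C#N)c2c1` gives 1000 nM, and compound 3 `Cc1[nH]c2ccccc2c1C=C(C#N)C#N` gives 56000 nM; both lie beyond the scatter above compound 1. Compound 4 `N#C/C(=C\c1c(-c2ccccc2)[nH]c2ccccc12)S(=O)(=O)c1ccccc1` differs from compound 1 by hydrogen in place of methoxy on an aromatic carbon. For the measured compounds named here, no measured pair differs only at this spot, so the data give no direct precedent for the size of such a step. Since only a small group is removed, a small step is expected, either none beyond the scatter or a modest move toward higher numbers. Compound 4 is expected to give 350 nM, within 120 nM to 1000 nM. The expected step of a 1.8-fold higher number from compound 1 to compound 4 (0.24 log units; within the scatter) would stay close to the scatter.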

Compound 4, half-maximal effective concentration: 400 nM
The estimate for compound 4 lay 1.1-fold (0.06 log units) below the measured number; the measured number falls inside the stated range.
By their numbers in this assay, from the lowest: compounds 1 and 4 (each within the scatter of the next); then compound 2; then compound 3.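

Swapping 4-methoxyphenyl for phenyl gives a 2.0-fold higher number from compound 1 to compound 4 (0.30 log units; within the scatter) in this assay, the first direct comparison at this position. The step stays within the usual scatter, so these two compounds cannot be told apart, and the methoxy is not required for a value in this range. No supporting measurement bears on what lies behind this result.

Going by these compounds, whether groups other than hydrogen and methoxy would fit equally well here remains open; an amine or a carboxylic acid at this spot could give a quite different number. This single step also says nothing about changes elsewhere on the shared core.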